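This account rests on a few compounds, and the source may have more. Where it says the series, first, only, none or still open, it means among the compounds named here.

Measured compounds and their values in a functional assay on MCF7 cells (Homo sapiens) for cytotoxicity, read by CCK-8 assay, with a stated time of 24 h; a lower number here means a stronger inhibitor, a higher number a weaker inhibitor:

- compound 1, `C/C(=C\c1cc(C2=CCCCC2)co1)C(N)=O`: 6580 nM
- compound 2, `C/C(=C\c1cc(-c2ccccc2)cs1)C(N)=O`: 2680 nM
- compound 3, `C/C(=C\c1cc(-c2ccccc2C)cs1)C(N)=O`: 4920 nM

Among these three, compound 2 carries the lowest number. Compound 3 lies nearest to it, and that gap is within the scatter, so the two cannot be ranked against each other; compound 1 lies furthest away, and that gap is beyond the scatter.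

The unmeasured compound 4, `C/C(=C\c1cc(-c2ccc(S(C)(=O)=O)cc2)cs1)C(N)=O`, is derived from compound 2 by a single change: methylsulfonyl in place of hydrogen on an aromatic carbon. Among the measured compounds shown here, only one measured step bears on this, the change on the same six-membered ring that turns compound 2 into compound 3: a 1.8-fold higher number from compound 2 to compound 3 (0.26 log units; within the scatter). That step swapped in a small group and left the number essentially unchanged. The group entering in compound 4 is larger and brings two hydrogen-bond acceptors, but nothing measured here shows what such a group does to this assay. The expectation is therefore a step no larger than the scatter, with a wide range to allow for the unknown: a 1.5-fold higher number from compound 2 to compound 4 (0.17 log units; within the scatter) is the expected step. Compound 4 is thus estimated at 4000 nM, between 1500 nM and 12000 nM.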

Compound 4, half-maximal inhibitory concentration: > 50000 nM
Compound 4 was reported as a limit; the forecaster's own chance of this, stated with the estimate: 5%; middle value at least 12-fold (1.09 log units) away from the limit.
By their numbers in this assay, from the lowest: compounds 2, 3 and 1 (each within the scatter of the next, the first and the last beyond it). At a limit, above all of these: compound 4.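

In this assay compound 4 is reported only as a limit, > 50000 nM, and not as a number. This shows that the six-membered aromatic ring is not indifferent to what it carries: methylsulfonyl in place of hydrogen, para to a large group, gives an at least 18-fold higher number from compound 2 to compound 4 (1.27 log units; beyond the scatter), whereas the earlier methyl change on the same ring gave only a 1.8-fold higher number from compound 2 to compound 3 (0.26 log units; within the scatter). Compound 4 is the only one shown that reaches this ceiling: the limit of > 50000 nM in this assay, at which 1 of the 4 values shown sits.

From the compounds shown here alone, it remains open whether a methoxy group, a fluorine atom, an amine or a carboxylic acid at this place would keep the number close to that of compound 2. The compounds shown also cannot tell which part of methylsulfonyl, its sulfur, its oxygens or its overall size, goes with the large step.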